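Extending a Methyl to Ethyl on the Shared Core

A few compounds are considered here, and "the series" means these few. Any claim that something is new, unique, unknown or untested is made for them only; others in the source may bear on it.

Compound 1 `Cn1c(C2CC2)nc2ccc(-n3ccc(OCc4ccc(Cl)cc4)cc3=O)cc21`: 21 nM
Compound 2 `Cc1nc2ccc(-n3ccc(OCc4ccc(F)cc4)cc3=O)cc2n1C`: 65 nM

In an assay on CHO cells for displacement of a labelled ligand from melanin-concentrating hormone receptor 1 (Rattus norvegicus), read by scintillation counting, with a stated time of 1 h (on this read-out lower numbers stand for stronger inhibition and higher numbers for weaker inhibition), compound 1 gives 21 nM and compound 2 gives 65 nM, so compound 2 holds the higher of the two numbers, a gap that lies beyond the usual scatter. Compound 3 `CCc1nc2ccc(-n3ccc(OCc4ccc(F)cc4)cc3=O)cc2n1C` differs from compound 2 by methyl in place of hydrogen on a saturated chain carbon bound to an aromatic carbon. Going by the values given here, no measured pair shows a step of this kind, so its direction cannot be read from the data; the step of a 1.2-fold lower number from compound 2 to compound 3 (0.07 log units; within the scatter) is expected to stay within the scatter. Compound 3 is expected to give about 55 nM in this assay, within a range from 25 nM to 130 nM.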

Compound 3, half-maximal inhibitory concentration: 38 nM
The estimate for compound 3 lay 1.4-fold (0.16 log units) above the measured number; measured number inside the range.
By their numbers in this assay, from the lowest: compounds 1, 3 and 2 (each within the scatter of the next, the first and the last beyond it).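

In this assay, methyl in place of hydrogen on a saturated chain carbon bound to an aromatic carbon gives a 1.7-fold lower number from compound 2 to compound 3 (0.23 log units; within the scatter) and turns methyl into ethyl. This position therefore accepts one more carbon without a shift beyond the scatter. The data offer no explanation for this result.
From the compounds shown here alone, whether a longer chain, an amine or a carboxylic acid would be accepted here remains open. Compound 1 carries cyclopropyl at this position but also chlorine in place of fluorine, so its number cannot separate those two differences.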